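From bromo to amino on the shared core

The source may hold more compounds than are shown below. What is called first, only, known or untested is meant among the compounds shown, and "the series" means these compounds.

In a functional assay on K562 cells (Homo sapiens) for cytotoxicity (a lower number here means a stronger inhibitor, a higher number a weaker inhibitor), compound 1 `CCC(CO)Nc1nc(NCc2ccccc2)c2nc(Cl)n(C(C)C)c2n1` gives 91000 nM as its value, compound 2 `CCC(CO)Nc1nc(NCc2cccc(O)c2)c2nc(Cl)n(C(C)C)c2n1` gives 27000 nM as its value, and compound 3 `CCC(CO)Nc1nc(NCc2ccccc2)c2nc(Br)n(C(C)C)c2n1` gives 27000 nM as its value. Compound 3 stands level with compound 2, and both lie beyond the scatter under compound 1.

Compound 4 `CCC(CO)Nc1nc(NCc2ccccc2)c2nc(N)n(C(C)C)c2n1` carries amino in place of bromo on an aromatic carbon in the spot between two ring nitrogen atoms. The closest evidence is the swap of chloro for bromo on that same carbon, where a 3.4-fold lower number from compound 1 to compound 3 (0.53 log units; beyond the scatter) is a modest step. The hydroxy swap elsewhere in the molecule, a 3.4-fold lower number from compound 1 to compound 2 (0.53 log units; beyond the scatter) as a step, is also modest. For the measured compounds named here, no measured compound has amino on this carbon, so the direction is uncertain. Compound 3 holds the lower of the two values known for this carbon, so a modest rise is the expectation. The expected change is a 2.0-fold higher number from compound 3 to compound 4 (0.31 log units; beyond the scatter) as a modest step. For compound 4 the expected value is 55000 nM in an estimated range from 18000 nM up to 150000 nM at its ends.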

Compound 4, half-maximal inhibitory concentration: 80000 nM
Estimate against measurement, compound 4: 1.5-fold (0.16 log units) below; low and high end bracket the measured number.
By their numbers in this assay, from the lowest: compounds 2 and 3 (each within the scatter of the next); then compounds 4 and 1 (each within the scatter of the next).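

On this carbon of the shared core, bromo had looked better than chloro, and amino does not keep that gain: amino in place of bromo gives a 3.0-fold higher number from compound 3 to compound 4 (0.47 log units; beyond the scatter) in this assay. Amino in place of chloro gives a 1.1-fold lower number from compound 1 to compound 4 (0.06 log units; within the scatter), so these two groups cannot be told apart here, and of the three groups seen on this carbon only bromo stands apart. Nothing available explains why bromo differs from the other two.

The compounds shown hold only chloro, bromo and amino on this carbon, so it remains open where iodo, methoxy or a methylamino group would fall. From the compounds shown here alone, it is also open whether bromo on this carbon and hydroxy on the benzyl ring would add up if carried by one molecule.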